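The compounds below may be only part of what the source reports. "The series", "measured", "known", "first", "only" and "open" are said of these compounds alone.

In a functional assay on PC-12 cells (Rattus norvegicus) for cytotoxicity, read by MTT assay, with stated times of 2 h and 24 h, tested at 1 uM (a higher number here means a stronger effect of the compound at the concentration tested, a lower number a weaker effect), two compounds have so far been measured, both built on the same core and differing only in the aromatic group carried on one nitrogen of that core. Compound 1 `CC(C)(C)c1ccc(-n2nc(-c3ccc(C(F)(F)F)cc3O)nc2-c2ccccc2O)cc1` gives 67.3%. Compound 2 `COc1cccc(-n2nc(-c3ccc(C(F)(F)F)cc3O)nc2-c2ccccc2O)c1` gives 68.3%. The step of a number 1 percentage points higher from compound 1 to compound 2 (within the scatter) is within the scatter, so the two numbers cannot be told apart; compound 2 stands alongside compound 1 rather than clearly apart from it.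

Compound 3 `Oc1cc(C(F)(F)F)ccc1-c1nc(-c2ccccc2O)n(-c2ccc(F)cc2F)n1` has not yet been measured. It differs from compound 2 only at that same nitrogen, as follows: 2,4-difluorophenyl in place of 3-methoxyphenyl on an aromatic nitrogen. Going by the values given here, the one measured step that bears on this place, the step of a number 1 percentage points higher from compound 1 to compound 2 (within the scatter), was also a swap of one aromatic group for another at this nitrogen and left the read-out essentially unchanged. On that basis the expected step of a number 1.3 percentage points lower from compound 2 to compound 3 (within the scatter) is small, in neither direction beyond the scatter. Compound 3 is therefore estimated to give 67%, with a likely range from 53% to 80%.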

Compound 3, a percentage reported as activity, at one concentration (the size of the read-out at that concentration, not a potency): 65.9%
Compound 3: the middle estimate sits 1.1 percentage points above what was measured; the measured number falls inside the stated range.
By their numbers in this assay, from the lowest: compounds 3, 1 and 2 (each within the scatter of the next).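

In this assay, putting 2,4-difluorophenyl on the aromatic nitrogen gives a number 2.4 percentage points lower from compound 2 to compound 3 (within the scatter) and a number 1.4 percentage points lower from compound 1 to compound 3 (within the scatter), so neither step can be told apart from repeated-measurement noise. The earlier pair held only carbon and oxygen in the changing group, whereas this one brings in fluorine and, compared with 3-methoxyphenyl, has no hydrogen-bond acceptor; even so, the three compounds remain indistinguishable at this one concentration, and that is all the numbers show about this position. No accompanying measurement speaks to what lies behind this flat result.

As far as these compounds go, all three compounds carry a six-membered aromatic ring of carbon at this nitrogen, so it remains open whether an aliphatic group such as cyclohexyl or a short alkyl chain, or a phenyl ring bearing an amine or a carboxylic acid, would shift the read-out. The trifluoromethyl group and the two hydroxyl groups stay the same throughout, which leaves their contribution to the read-out open as well.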